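The source may report more compounds than this note shows. Statements on the series, on what has been measured and on what is new or still open speak of the compounds shown alone.

Three close relatives have been measured in a functional assay on A-431 cells (Homo sapiens) for cytotoxicity, read by MTT assay, with a stated time of 48 h; on this read-out higher numbers stand for weaker inhibition and lower numbers for stronger inhibition. Compound 1 `CCCCCCCCCCCCCCNC(=O)[C@@H](NC(=O)c1ccccc1)[C@@H](C)O` gives 118000 nM, compound 2 `CCCCCCCCCCCCCCNC(=O)[C@@H](NS(=O)(=O)c1ccc(C)cc1)[C@@H](C)O` gives 12000 nM, and compound 3 `CCCCCCCCCCCCCCNC(=O)[C@@H](NS(=O)(=O)c1ccc2ccccc2c1)[C@@H](C)O` gives 19600 nM. Within the data shown here, compound 2 thus holds the lowest of the three numbers, but only the step to compound 1 is a clear one: a 9.8-fold lower number from compound 1 to compound 2 (0.99 log units; beyond the scatter). The step from compound 2 onward to compound 3, a 1.6-fold higher number from compound 2 to compound 3 (0.21 log units; within the scatter), stays within the scatter, so those two compounds cannot be ranked against each other.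

Compound 4 `CCCCCCCCCCCCCCCCCCNC(=O)[C@@H](NS(=O)(=O)c1ccc(C)cc1)[C@@H](C)O` keeps everything in compound 2 except the long saturated chain, which is extended by one change: butyl in place of hydrogen on a saturated chain carbon, ten or more bonds along the chain from an amide-type nitrogen. Neither measured step touches this chain; both alter the group on the amine nitrogen, one modestly, one within the scatter. Among the measured compounds shown here, there is therefore no measured step that speaks directly to a longer chain, and the safest reading is that the chain extension brings no step beyond the scatter in this assay.

On that basis compound 4 is expected to give about 12000 nM, with a likely range from 4000 nM to 36000 nM. This estimate means a step of no change at the digits printed from compound 2 to compound 4 (within the scatter), which is expected to fall within the scatter.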

Compound 4, half-maximal inhibitory concentration: 34000 nM
Compound 4: the middle estimate sits 2.8-fold (0.45 log units) below what was measured; the measured number falls inside the stated range.
By their numbers in this assay, from the lowest: compounds 2, 3 and 4 (each within the scatter of the next, the first and the last beyond it); then compound 1.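

In this assay, among these compounds, the long saturated chain proves to matter as well as the group on the amine nitrogen, the only part varied among the earlier compounds: butyl in place of hydrogen on a saturated chain carbon, ten or more bonds along the chain from an amide-type nitrogen, gives a 2.8-fold higher number from compound 2 to compound 4 (0.45 log units; beyond the scatter) and so a modest loss of inhibition. This single step shows that making the chain longer did not strengthen inhibition in this pair, although it says nothing about other chain lengths or other groups on the amine nitrogen. Nothing measured alongside these numbers bears on this step, so the result stands without an explanation.

A single pair cannot show whether the number climbs steadily with chain length, or whether a shorter chain, such as octyl, would give a lower number than compound 2 does. From the compounds shown here alone, it also remains open whether the same butyl extension would shift the number similarly with benzoyl or naphthalen-2-ylsulfonyl on the amine nitrogen, or how a terminal amine or carboxylic acid on the chain would behave.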